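From Hydroxy to Methoxy on Compound 1

The compounds below may be only part of what the source reports. "The series", "measured", "known", "first", "only" and "open" are said of these compounds alone.

Among the compounds with values here, in an ADME assay on LLC-PK1 cells (Sus scrofa) for cytotoxicity, read by neutral red uptake (on this read-out lower numbers stand for stronger inhibition and higher numbers for weaker inhibition), compound 1 `COC(/C=C/c1ccc(O)cc1)=C1\C(=O)C=C(C)C1=O` gives 3.4 ug/mL, the only actual number so far. Compound 2 `CO/C(=C1\C(=O)C=C(C)C1=O)c1ccccc1` reads > 10 ug/mL, and this is a limit, not a number. Compound 1 therefore has no measured neighbour to be compared with step by step.

Next comes compound 3 `COC(/C=C/c1ccc(OC)cc1)=C1\C(=O)C=C(C)C1=O`, which keeps the core of compound 1 and alters one small spot: methyl in place of hydrogen on an oxygen on an aromatic ring, so hydroxy becomes methoxy. Within the data shown here, no measured pair shows this change, so the guidance is thin. In this assay, a small shift toward weaker inhibition is expected, possibly no larger than the usual scatter. The expected change is a 1.3-fold higher number from compound 1 to compound 3 (0.12 log units; within the scatter). For compound 3 the estimated value is 4.5 ug/mL, within an expected range of 2 ug/mL to 10 ug/mL.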

Compound 3, half-maximal inhibitory concentration: 3.9 ug/mL
Compound 3: middle estimate off by 1.2-fold (0.06 log units), on the high side, within the range that was stated.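

In this assay, putting methyl on the oxygen of the aromatic ring, which turns hydroxy into methoxy, gives a 1.1-fold higher number from compound 1 to compound 3 (0.06 log units; within the scatter) and so leaves the read-out essentially where it was. Within the data shown here, this is the first pair here that differs in only one place, and it shows that, in this pair, the hydrogen on that oxygen can be replaced by methyl with no change beyond the usual scatter. Nothing measured here offers a reason why the two compounds read alike, so this stays a plain observation.

A single pair cannot show how far this tolerance extends at this oxygen. As far as these compounds go, whether a longer chain such as butyl, or a group carrying an amine or a carboxylic acid, would read the same at this position remains open.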